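Swapping methyl for chloro on the aryl ring of compound 1

The compounds below may be only part of what the source reports. "The series", "measured", "known", "first", "only" and "open" are said of these compounds alone.

Going by the values given here, compound 1 `Cc1ccc(Nc2nc(SCc3cn(CC(=O)NC(=O)Nc4ccccn4)nn3)nc(-c3ccc(C)cc3)c2C#N)cc1` is the stronger of the two compounds measured so far: in a functional assay on B16-F10 cells (Mus musculus) for inhibition, read by MTT assay, with a stated time of 72 h (a higher number here means a weaker inhibitor, a lower number a stronger inhibitor), compound 1 gives 1010 nM. Compound 2 `Cc1ccc(-c2nc(SCc3cn(CC(=O)NC(=O)Nc4ccccn4)nn3)nc(Nc3cccc(Cl)c3)c2C#N)cc1`, which differs at the nitrogen-linked ring, gives 7580 nM, and the step of a 7.5-fold higher number from compound 1 to compound 2 (0.88 log units; beyond the scatter) is modest. Compound 3 `Cc1ccc(Nc2nc(SCc3cn(CC(=O)NC(=O)Nc4ccccn4)nn3)nc(-c3ccc(Cl)cc3)c2C#N)cc1` carries instead the change (chloro in place of methyl on an aromatic carbon), on an aromatic carbon of a six-membered aromatic ring of carbon only, para to a large group. Among the compounds with values here, no measured step touches this position, so the only guide is that a ring change elsewhere cost potency. A small loss is expected, a 1.5-fold higher number from compound 1 to compound 3 (0.17 log units; within the scatter), giving an estimated 1500 nM for compound 3, within 500 nM to 5000 nM.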

Compound 3, half-maximal inhibitory concentration: 1320 nM
For compound 3 the middle estimate is 1.1-fold (0.06 log units) above the measured one; low and high end bracket the measured number.
By their numbers in this assay, from the lowest: compounds 1 and 3 (each within the scatter of the next); then compound 2.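

In this assay the swap of 4-methylphenyl to 4-chlorophenyl is a 1.3-fold higher number from compound 1 to compound 3 (0.12 log units; within the scatter) and so cannot be told apart from repeat measurement. This position on the ring therefore takes chloro in place of methyl with no visible change in the number. Nothing available explains why the two groups read alike.

Only these two small groups are shown at this position. On these data alone, how a methoxy group, an amine, a carboxylic acid or a longer alkyl chain would read there remains open.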